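Extending the Methyl of Compound 3 with a Dimethylamino Group

The source may hold more compounds than are shown below. What is called first, only, known or untested is meant among the compounds shown, and "the series" means these compounds.

Compound 1, `Cc1cnc(C(=O)Nc2cccc3ccc(C)nc23)cn1`: > 10000 nM in a functional assay on BXPC-3 cells (Homo sapiens) for inhibition, read by MTT assay, with a stated time of 72 h; on this read-out lower numbers stand for stronger inhibition and higher numbers for weaker inhibition
Compound 2, `COc1cc(NC(=O)c2cnc(C)cn2)c2ncccc2c1`: 6700 nM in this assay
Compound 3, `Cc1ccc2cccc(NC(=O)c3cnccn3)c2n1`: > 10000 nM in this assay

Compound 3 stands at the edge of what this assay reports: its value of > 10000 nM is a limit, not a number. Compound 1 likewise returns only a limit, > 10000 nM. Among the measured compounds shown here, compound 2 is the single compound with a measured number, 6700 nM. For the measured compounds named here, the one step between measured neighbours, a step that the two limits leave unreadable from compound 1 to compound 3, cannot be sized, since both ends sit at the limit of > 10000 nM in this assay, at which 2 of the 3 values shown sit.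

Compound 4, `CN(C)Cc1ccc2cccc(NC(=O)c3cnccn3)c2n1`, differs from compound 3 by dimethylamino in place of hydrogen on a saturated chain carbon bound to an aromatic carbon; cut one bond further out, the change reads methyl to (dimethylamino)methyl. None of the measured steps bears on this change, and the only step shown concerns a methyl on an aromatic carbon with a size that is not readable. With no measured guide, the step of an at least 1.2-fold lower number from compound 3 to compound 4 (0.09 log units; that floor lies within the scatter) is expected to stay small in this assay. Compound 4 is therefore estimated at 8000 nM, within a range from 2000 nM to 30000 nM, and a further limit-only result remains a real possibility.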

Compound 4, half-maximal inhibitory concentration: > 10000 nM
Compound 4 was reported as a limit (the forecaster's own chance of this, stated with the estimate: 50%); middle value at least 1.2-fold (0.09 log units) away from the limit.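

In this assay compound 4 returns > 10000 nM as a limit and not a number. Compound 3 also returns only a limit, and the step between compound 3 and compound 4 cannot be read. The compounds shown leave open whether in this assay dimethylamino in place of hydrogen shifts the read-out at all.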